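Chain terminus variations on a spiro-piperidine series

A few compounds are considered here, and "the series" means these few. Any claim that something is new, unique, unknown or untested is made for them only; others in the source may bear on it.

Measured so far:
compound 1 `CC(C)(C)OC(=O)NCCCNC(=O)CN1CN(c2ccccc2)C2(CCN(C(=O)c3ccc(C4CCCCC4)cc3)CC2)C1=O`: 6000 nM
compound 2 `COC(=O)CCCNC(=O)CN1CN(c2ccccc2)C2(CCN(C(=O)c3ccc(C4CCCCC4)cc3)CC2)C1=O`: 2500 nM
compound 3 `O=C(CN1CN(c2ccccc2)C2(CCN(C(=O)c3ccc(C4CCCCC4)cc3)CC2)C1=O)NCCO`: 2000 nM

All three compounds share one core and differ only in the chain beyond the amide-type nitrogen. In an assay on HEK293 cells for displacement of a labelled ligand from NPC1-like intracellular cholesterol transporter 1 (Homo sapiens) (a higher number here means a weaker inhibitor, a lower number a stronger inhibitor), compound 3 gives the lowest of the three numbers, though its gap to compound 2 lies within the scatter (a 1.3-fold lower number from compound 2 to compound 3 (0.10 log units; within the scatter)); only the gap to compound 1 is beyond it (a 3.0-fold lower number from compound 1 to compound 3 (0.48 log units; beyond the scatter)).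

Compound 4 `CC(C)(C)OC(=O)NCCCCNC(=O)CN1CN(c2ccccc2)C2(CCN(C(=O)c3ccc(C4CCCCC4)cc3)CC2)C1=O` carries 2-((tert-butoxycarbonyl)amino)ethyl in place of hydroxy on a saturated chain carbon, two bonds along the chain from an amide-type nitrogen. The change is the reverse of the step of a 3.0-fold lower number from compound 1 to compound 3 (0.48 log units; beyond the scatter), extended by one chain carbon; the step of a 2.4-fold lower number from compound 1 to compound 2 (0.38 log units; beyond the scatter) points the same way. A rise of similar size is therefore expected for compound 4: a 2.5-fold higher number from compound 3 to compound 4 (0.40 log units; beyond the scatter), giving an estimate of 5000 nM with a range of 2000 nM to 12000 nM.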

Compound 4, half-maximal inhibitory concentration: 4600 nM
For compound 4 the middle estimate is 1.1-fold (0.04 log units) above the measured one; measured number inside the range.
By their numbers in this assay, from the lowest: compounds 3, 2, 4 and 1 (each within the scatter of the next, the first and the last beyond it).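

In this assay, the 2-((tert-butoxycarbonyl)amino)ethyl end remains separated from hydroxy (a 2.3-fold higher number from compound 3 to compound 4 (0.36 log units; beyond the scatter)), so the gap seen with the (tert-butoxycarbonyl)amino chain of compound 1 persists with one further chain carbon. That extra carbon gives no readable difference (a 1.3-fold lower number from compound 1 to compound 4 (0.12 log units; within the scatter)), and the methoxycarbonyl and (tert-butoxycarbonyl)amino ends are not told apart either (a 1.8-fold higher number from compound 2 to compound 4 (0.26 log units; within the scatter)). Nothing available accounts for these steps.

Open, as far as these compounds go, is whether a free amine or a carboxylic acid at the chain end would fall with hydroxy or with the (tert-butoxycarbonyl)amino ends. Also open, from the compounds shown here alone, is how a longer chain ending in hydroxy would read.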